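Cytotoxicity series: aryl-triazole ethers on the shared core

The source may report more compounds than this note shows. Statements on the series, on what has been measured and on what is new or still open speak of the compounds shown alone.

Measured so far:
compound 1 `COc1ccccc1-n1cc(COc2c(/C=C\C(=O)O)ccc(OC)c2CC=C(C)C)nn1` gives 32600 nM in a functional assay on A-431 cells (Homo sapiens) for cytotoxicity, read by MTT assay, with a stated time of 24 h; a lower number here means a stronger inhibitor, a higher number a weaker inhibitor
compound 2 `COc1cccc(-n2cc(COc3c(/C=C\C(=O)O)ccc(OC)c3CC=C(C)C)nn2)c1` gives 23200 nM in this assay

Compound 1 has the highest of the two numbers, and its nearest neighbour is compound 2, with the step of a 1.4-fold lower number from compound 1 to compound 2 (0.15 log units; within the scatter) between them; the two values are therefore indistinguishable within the scatter.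

Compound 3 `COc1ccc(/C=C\C(=O)O)c(OCc2cn(-c3cccc(C#N)c3)nn2)c1CC=C(C)C` is not yet measured. It differs from compound 1 in one place: 3-cyanophenyl in place of 2-methoxyphenyl on an aromatic nitrogen. Going by the values given here, the single measured step, from compound 1 to compound 2, moves the methoxy around the ring and stays within the scatter; no measured step replaces the methoxy by a nitrile, so that change is without precedent here. Among the compounds with values here, with only one neutral step to go on, no movement beyond the scatter is expected in this assay, and the estimated step is a 1.2-fold lower number from compound 1 to compound 3 (0.07 log units; within the scatter). For compound 3 the expected value is 28000 nM, in a range from 10000 nM to 80000 nM.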

Compound 3, half-maximal inhibitory concentration: 22900 nM
Beside the measured number, compound 3's estimate is 1.2-fold (0.09 log units) above it; the measured number falls inside the stated range.
By their numbers in this assay, from the lowest: compounds 3, 2 and 1 (each within the scatter of the next).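

In this assay, 3-cyanophenyl in place of 2-methoxyphenyl on the aromatic nitrogen gives a 1.4-fold lower number from compound 1 to compound 3 (0.15 log units; within the scatter), and cyano in place of methoxy on an aromatic carbon gives a 1.0-fold lower number from compound 2 to compound 3 (0.01 log units; within the scatter). The earlier pair covered only a move of the methoxy group on the phenyl ring, whereas these steps exchange that group for a nitrile, and compound 1, compound 2 and compound 3 still cannot be told apart within the scatter. No supporting data bear on this result.

Going by these compounds, whether an amine, a carboxylic acid or a longer chain on the phenyl ring would give a similar number remains open. The compounds shown also leave open whether any change at this position can move the number beyond the scatter.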